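The source may hold more compounds than are shown below. What is called first, only, known or untested is meant among the compounds shown, and "the series" means these compounds.

Within the data shown here, compound 2 `Cc1nc(C(c2ccc(-c3ccc4cccc(F)c4c3)[nH]c2=O)C(C)C)[nH]c1C` gives 0.268 h in an ADME assay on microsomes from liver (Homo sapiens) for metabolic stability (on this read-out higher numbers stand for a longer-lived compound and lower numbers for a shorter-lived compound), the lowest of the two numbers known there; compound 1 `CCn1ncc2c(F)cc(-c3ccc(C(CC)(CC)c4nncn4C)c(=O)[nH]3)cc21` gives 2.67 h in this assay, a gap beyond the scatter. For compound 3 `CCn1ncc2c(F)cc(-c3ccc(C(CC)(CC)c4ncn(C)n4)c(=O)[nH]3)cc21` this assay reports only a limit, > 3 h, which is the limit of > 3 h in this assay, at which 1 of the 3 values shown sits. Among the measured compounds shown here, the single measured step, an at least 1.1-fold higher number from compound 1 to compound 3 (0.05 log units; that floor lies within the scatter), concerns a different change on a different core and lies within the scatter. The change from compound 2 to compound 4 `Cc1c[nH]c(C(c2ccc(-c3ccc4cccc(F)c4c3)[nH]c2=O)C(C)C)n1` is hydrogen in place of methyl on an aromatic carbon. For the measured compounds named here, no measured step bears on this change, so a step of no more than the scatter is expected, in no set direction. Compound 4 is therefore expected at 0.3 h in this assay, with a range of 0.12 h to 0.7 h and an expected step of a 1.1-fold higher number from compound 2 to compound 4 (0.05 log units; within the scatter).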

Compound 4, half-life: 0.09 h
Estimate against measurement, compound 4: 3.3-fold (0.52 log units) above; measured number outside the range, below it.
By their numbers in this assay, from the lowest: compound 4; then compound 2; then compound 1. At a limit, above all of these: compound 3.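

Hydrogen in place of methyl on this aromatic carbon gives a 3.0-fold lower number from compound 2 to compound 4 (0.47 log units; beyond the scatter) in this assay, the first measured step beyond the scatter in the series. This position on the imidazole-bearing side is therefore not indifferent to the change, and the 4,5-dimethyl-1H-imidazol-2-yl group gives the longer-lived compound of this pair. Nothing measured here accounts for the step. Going by these compounds, whether a longer chain such as ethyl, or a fluorine atom, on this carbon would shift the half-life remains open. So does whether the same change would act alike on the core of compound 1.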